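Chloro for Dimethylamino: Expected Maximal Response of Compound 3

The source may hold more compounds than are shown below. What is called first, only, known or untested is meant among the compounds shown, and "the series" means these compounds.

Compound 1 `Cc1nc(Cc2cccc(C(F)(F)F)c2)sc1-c1ccc(C(N)=O)cn1`: 70%
Compound 2 `Cc1cc(-c2sc(Cc3cccc(N(C)C)c3)nc2C)ccc1C(N)=O`: 101%

Within the data shown here, in a functional assay on cells for agonist activity at G-protein coupled receptor 52 (Homo sapiens), read by AlphaScreen and cAMP accumulation, with a stated time of 30 min (on this read-out lower numbers stand for smaller maximal responses and higher numbers for larger maximal responses), compound 2 gives 101%, the higher of the two numbers measured so far; compound 1 sits a number lower, a gap beyond the usual scatter. Compound 3 `Cc1cc(-c2sc(Cc3cccc(Cl)c3)nc2C)ccc1C(N)=O` differs from compound 2 by a single change: chloro in place of dimethylamino on an aromatic carbon. Among the measured compounds shown here, no measured pair shows this change, so its effect is unknown. A modest fall is expected, with the step of a number 13 percentage points lower from compound 2 to compound 3 (beyond the scatter) lying close to the edge of the scatter. Compound 3 is therefore estimated to reach 88%, with a range from 60% to 110%.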

Compound 3, largest response reached (Emax), in percent of the reference or control that the assay uses: 75%
Compound 3: the middle estimate sits 13 percentage points above what was measured, within the range that was stated.
By their numbers in this assay, from the lowest: compounds 1 and 3 (each within the scatter of the next); then compound 2.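

In this assay, chloro in place of dimethylamino on an aromatic carbon gives a number 26 percentage points lower from compound 2 to compound 3 (beyond the scatter). This single pair shows that the maximal response depends on the group at this place, meta to a large group, and that dimethylamino cannot be swapped for chloro without a loss. Nothing available explains the fall.

On these data alone, with only these two groups compared, it remains open how a primary amine, a methoxy group or a carboxylic acid at this place would perform. As far as these compounds go, whether the step would carry over to the core of compound 1 also remains open.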